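Swapping a dimethoxyphenyl end for plain phenyl

The source may report more compounds than this note shows. Statements on the series, on what has been measured and on what is new or still open speak of the compounds shown alone.

Measured so far:
Compound 1, `COc1ccc(-c2ccc(-c3ccc(-c4nc5cc(C)ccc5[nH]4)cc3)cc2)cc1OC`, gives 1720 nM in a functional assay on DWD cells (Homo sapiens) for inhibition, read by sulforhodamine B assay; a higher number here means a weaker inhibitor of growth, a lower number a stronger inhibitor of growth.
Compound 2, `Oc1cccc2[nH]c(-c3ccc(-c4ccc(-c5ccccc5)cc4)cc3)nc12`, gives 9680 nM.
Compound 3, `COc1ccc(-c2ccc(-c3ccc(-c4nc5c(O)cccc5[nH]4)cc3)cc2)cc1OC`, gives 1400 nM.

Compounds 3 and 2 differ by one change, (phenyl in place of 3,4-dimethoxyphenyl on an aromatic carbon), and that change made a 6.9-fold higher number from compound 3 to compound 2 (0.84 log units; beyond the scatter). Compound 4, `Cc1ccc2[nH]c(-c3ccc(-c4ccc(-c5ccccc5)cc4)cc3)nc2c1`, is not yet measured; it differs from compound 1 by phenyl in place of 3,4-dimethoxyphenyl on an aromatic carbon, the same change at the same kind of place. The two starting cores differ by 5-methyl-1H-benzimidazol-2-yl in place of 4-hydroxy-1H-benzimidazol-2-yl on an aromatic carbon, a change that made a 1.2-fold lower number from compound 1 to compound 3 (0.09 log units; within the scatter), so the cores behave alike. Because the earlier step was a 6.9-fold higher number from compound 3 to compound 2 (0.84 log units; beyond the scatter), the expected step from compound 1 to compound 4 in this assay is a 6.4-fold higher number from compound 1 to compound 4 (0.81 log units; beyond the scatter). Compound 4 is therefore estimated at 11000 nM, expected to fall between 4000 nM and 30000 nM.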

Compound 4, concentration for 50% growth inhibition: 28300 nM
For compound 4 the middle estimate is 2.6-fold (0.41 log units) below the measured one; low and high end bracket the measured number.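

On the core of compound 1, phenyl in place of 3,4-dimethoxyphenyl gave a 16-fold higher number from compound 1 to compound 4 (1.22 log units; beyond the scatter) in this assay and so again produced a weaker inhibitor of growth, as it did on the other core. The two steps point the same way, and their sizes cannot be told apart: the same change on two cores in this assay, a 6.9-fold higher number (0.84 log units; beyond the scatter) from compound 3 to compound 2 and a 16-fold higher number (1.22 log units; beyond the scatter) from compound 1 to compound 4, 2.4-fold (0.38 log units) apart, within the scatter of two such steps This shows that the loss carries over between these two cores, but it does not show that it would carry to any other core, or what in the 3,4-dimethoxyphenyl group accounts for it.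

From the compounds shown here alone, it remains open whether a single methoxy group would keep any of the activity. Also open, going by these compounds, is how this assay would read an amine or a carboxylic acid in that place.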